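This account rests on a few compounds, and the source may have more. Where it says the series, first, only, none or still open, it means among the compounds named here.

Compound 1 `Cc1cn([C@@H]2O[C@H](CO[Si](C)(C)C(C)(C)C(C)C)[C@@]3(OS(=O)(=O)C=C3NC(=O)NC(=O)c3ccccc3)[C@H]2O[Si](C)(C)C(C)(C)C)c(=O)n(C)c1=O` is the starting point of this comparison. In an ADME assay on HEL cells (Homo sapiens) for cytotoxicity, with a stated time of 3 days (on this read-out lower numbers stand for higher toxicity in this test and higher numbers for lower toxicity in this test), compound 1 gives >= 100000 nM, which is a limit of the assay rather than a measured number. Compound 2 `Cc1cn([C@@H]2O[C@H](CO[Si](C)(C)C(C)(C)C(C)C)[C@@]3(OS(=O)(=O)C=C3NC(=O)NC(=O)c3ccccc3)[C@H]2O[Si](C)(C)C(C)(C)C(C)C)c(=O)n(C)c1=O` differs from compound 1 only by isopropyl in place of methyl on a saturated chain carbon bound to two saturated chain carbons and a silicon atom. In this assay compound 2 gives >= 100000 nM, again a limit of the assay. The step that the two limits leave unreadable from compound 1 to compound 2 therefore cannot be read in size or direction. Going by the values given here, both values rest on (the limit of >= 100000 nM in this assay, at which 2 of the 2 values shown sit), so compound 1 stands exactly where the only other measured compound stands, with no number of its own. Compound 3 `Cc1cn([C@@H]2O[C@H](COC(=O)c3ccccc3)[C@@]3(OS(=O)(=O)C=C3NC(=O)NC(=O)c3ccccc3)[C@H]2O[Si](C)(C)C(C)(C)C)c(=O)n(C)c1=O` differs from compound 1 by a group of 8 heavy atoms (7 carbon, 1 oxygen; one six-membered aromatic ring of carbon only) in place of a group of 9 heavy atoms (8 carbon, 1 silicon; no ring), on an oxygen on a saturated carbon. Among the compounds with values here, no measured step swaps a silicon-bearing group for a benzoyl, so the single step that exists offers neither a size nor a direction to lean on. Compound 3 is therefore expected to sit at the same limit, with a number no higher from compound 1 to compound 3 (the limit leaves the size open) expected to show nothing beyond the scatter. The estimate for compound 3 is 100000 nM, within a range from 30000 nM to 200000 nM.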

Compound 3, minimum cytotoxic concentration: >= 5000 nM
Compound 3: no number, only a limit; the forecaster's own chance of this, stated with the estimate: 80%; the middle value lies beyond the limit too.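

In this assay compound 3 gives >= 5000 nM, which is a limit of the assay and not a number. Compound 1 also stands only at a limit, so the step between compound 1 and compound 3 cannot be read. The compounds shown leave open whether benzoyl in place of the silicon-bearing group changes toxicity in this test at all.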